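The compounds below may be only part of what the source reports. "The series", "measured", "known", "first", "only" and "open" are said of these compounds alone.

Three compounds share one core and differ only in the chain bound to the aromatic nitrogen. Compound 1 `CCn1ccnc1-c1cccc(Cl)c1CCc1cc(Br)ccc1OC` gives 1800 nM in a functional assay on HEK293 cells (Homo sapiens), read by cAMP accumulation; a lower number here means a stronger inhibitor, a higher number a weaker inhibitor. Compound 2 `COc1ccc(Br)cc1CCc1c(Cl)cccc1-c1nccn1C(C)C` gives 1400 nM, and compound 3 `CCC(C)n1ccnc1-c1cccc(Cl)c1CCc1cc(Br)ccc1OC` gives 2100 nM; compound 1 thus stands second highest of the three, and every gap among them is within the scatter. Compound 4 `COc1ccc(Br)cc1CCc1c(Cl)cccc1-c1nccn1CC1CC1` carries cyclopropyl in place of methyl on a saturated chain carbon bound to an aromatic nitrogen. Going by the values given here, two measured steps touch that same carbon: a 1.3-fold lower number from compound 1 to compound 2 (0.11 log units; within the scatter) and a 1.2-fold higher number from compound 1 to compound 3 (0.07 log units; within the scatter), neither beyond the scatter. Enlarging the chain at that carbon has so far left the number where it was, so the step of a 1.1-fold lower number from compound 1 to compound 4 (0.05 log units; within the scatter) is expected to stay within the scatter. Compound 4 is therefore estimated at 1600 nM, with a range from 700 nM to 3600 nM.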

Compound 4, half-maximal inhibitory concentration: 1700 nM
The estimate for compound 4 lay 1.1-fold (0.03 log units) below the measured number, and the stated range covers the measured number.
By their numbers in this assay, from the lowest: compounds 2, 4, 1 and 3 (each within the scatter of the next).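

Compound 4 brings the first ring to the chain on the aromatic nitrogen, and in this assay that ring leaves the number in place, with a 1.1-fold lower number from compound 1 to compound 4 (0.02 log units; within the scatter) for cyclopropyl in place of methyl. Set against the branched chains it behaves no differently, with a 1.2-fold lower number from compound 3 to compound 4 (0.09 log units; within the scatter) and a 1.2-fold higher number from compound 2 to compound 4 (0.08 log units; within the scatter) as the other two steps, so open chains and this ring-bearing chain have so far read alike here. Nothing available explains this flat response. On these data alone, whether an amine, a carboxylic acid or a much longer chain at this position would move the number beyond the scatter stays open.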